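Pyridin-3-yl to pyridin-2-yl on an amine nitrogen

The source may hold more compounds than are shown below. What is called first, only, known or untested is meant among the compounds shown, and "the series" means these compounds.

These notes cover a small series sharing one core, followed in a functional assay on CWR22R cells (Homo sapiens) for antiproliferative activity, read by CCK-8 assay, with a stated time of 6 days; on this read-out lower numbers stand for stronger inhibition and higher numbers for weaker inhibition. Compound 1 `C[C@@H](Cn1ccc(-c2ccc(C#N)c(Cl)c2)n1)NC(=O)c1ccccc1F` offers no number to work with: the entry for compound 1 reads "not determined" (no result reported). Compound 2 `C[C@@H](Cn1ccc(-c2ccc(C#N)c(Cl)c2)n1)Nc1cccnc1` gives 21600 nM. Among the compounds with values here, that is the only number available so far, so compound 2 cannot yet be ranked against any other compound.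

The next compound to be read is compound 3 `C[C@@H](Cn1ccc(-c2ccc(C#N)c(Cl)c2)n1)Nc1ccccn1`. Its difference from compound 2 is pyridin-2-yl in place of pyridin-3-yl on an amine nitrogen. In words, pyridin-2-yl stands in place of pyridin-3-yl on an amine nitrogen, and the two compounds have the same atoms, joined differently.

Within the data shown here, no step between measured compounds exists here to show how far such a change can move this assay. The expectation therefore rests on compound 2 at 21600 nM alone. No direction is favoured, and no shift beyond the usual scatter is expected. The estimated change is a 1.1-fold lower number from compound 2 to compound 3 (0.03 log units; within the scatter), which is expected to stay within that scatter. For compound 3 the estimated value is 20000 nM, with an expected range of 8000 nM to 45000 nM.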

Compound 3, half-maximal inhibitory concentration: > 30000 nM
Compound 3: a limit, no number (the forecaster's own chance of this, stated with the estimate: 10%); middle value at least 1.5-fold (0.17 log units) away from the limit.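

In this assay, compound 3 gives > 30000 nM, which is a limit of the assay and not a number. Pyridin-2-yl in place of pyridin-3-yl on an amine nitrogen gives an at least 1.3-fold higher number from compound 2 to compound 3 (0.14 log units; that floor lies within the scatter), the first step that can be read at this position; only its floor is known, so the real size of the step stays undefined and may or may not exceed the usual variation between repeats. What this adds to the earlier entries is that this exchange of one pyridine attachment for the other gives no sign of a lower number, and that the series can reach the end of the measurable range at this position: the limit of > 30000 nM in this assay, at which 1 of the 3 values shown sits.

A number for compound 3 would be needed to say whether the attachment of the pyridine matters at all here, and compound 1 offers no reading by which to compare its 2-fluorobenzoyl amide with either amine. As far as these compounds go, how pyridin-4-yl or a plain phenyl ring on the same amine nitrogen would read in this assay remains open.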